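Taking the bromoethenyl carbonyl group off compound 2

A few compounds are considered here, and "the series" means these few. Any claim that something is new, unique, unknown or untested is made for them only; others in the source may bear on it.

In a functional assay on FM3A cells (Mus musculus) for antiproliferative activity, with a stated time of 48 h (on this read-out higher numbers stand for weaker inhibition and lower numbers for stronger inhibition), compound 1 `C=C(Br)C(=O)Nc1ccc(C(=O)/C=C/c2ccccc2)cc1` gives 690 nM and compound 2 `C=C(Br)C(=O)Nc1ccc(C(=O)/C=C/c2ccccc2OC)cc1` gives 370 nM so the two sit within the scatter of each other. Going to compound 3 `COc1ccccc1/C=C/C(=O)c1ccc(N)cc1` means hydrogen in place of (1-bromoethenyl)carbonyl on a nitrogen on an aromatic ring so hydrogen stands in place of (1-bromoethenyl)carbonyl on a nitrogen on an aromatic ring. Going by the values given here, the only measured step, a 1.9-fold lower number from compound 1 to compound 2 (0.27 log units; within the scatter) for methoxy in place of hydrogen on an aromatic carbon, does not touch this group, so it offers no direct guide. With so large a piece gone from compound 2 at 370 nM a clearly higher number, meaning weaker inhibition, is expected, an estimated 41-fold higher number from compound 2 to compound 3 (1.61 log units; beyond the scatter) in this assay with wide uncertainty. For compound 3 the estimate is 15000 nM with an expected range from 3000 nM to 60000 nM on this read-out.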

Compound 3, half-maximal inhibitory concentration: 25000 nM
Compound 3: the middle estimate sits 1.7-fold (0.22 log units) below what was measured; the range from low to high includes it.
By their numbers in this assay, from the lowest: compounds 2 and 1 (each within the scatter of the next); then compound 3.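

In this assay, taking the (1-bromoethenyl)carbonyl group off the nitrogen gives a 68-fold higher number from compound 2 to compound 3 (1.83 log units; beyond the scatter), so this group counts for much of the inhibition, and the free amino compound keeps only a weak effect. The earlier methoxy step stayed within the scatter and gave no sign of a change this large. Nothing available bears on the reason for this loss.

The whole group left in one step, so the parts played by the bromine, the double bond and the carbonyl stay unseparated. An acetyl group on the same nitrogen, with neither bromine nor double bond, would help to tell them apart.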